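The compounds below may be only part of what the source reports. "The series", "measured", "known", "first", "only" and "open" are said of these compounds alone.

In a functional assay on NCI-H226 cells (Homo sapiens) for inhibition, read by MTT assay, with a stated time of 48 h, tested at 10 uM (a higher number here means more inhibition at the concentration tested (going by the name of the read-out), a lower number less inhibition), the measured compounds stand as follows:
compound 1 `COc1cc(NC(=O)Nc2cc(Nc3ccc(C(C)(C)C)cc3)ncn2)cc(OC)c1` gives 47.7%;
compound 2 `Cc1ccc(Nc2cc(NC(=O)Nc3c(Cl)cccc3Cl)ncn2)cc1C` gives 41.3%;
compound 3 `COc1cc(NC(=O)Nc2cc(Nc3cc(F)ccc3OC)ncn2)cc(OC)c1` gives 37.7%.

Compound 2 holds the second highest of these three numbers, yet its gaps to compound 3 and to compound 1 both lie within the scatter, so the three compounds are not told apart here. Compound 4 `COc1ccc(Br)cc1Nc1cc(NC(=O)Nc2c(Cl)cccc2Cl)ncn1` is not yet measured. It differs from compound 2 in one place: 5-bromo-2-methoxyphenyl in place of 3,4-dimethylphenyl on a nitrogen on an aromatic ring. Going by the values given here, one measured step bears on this kind of exchange on the same nitrogen, a number 10 percentage points lower from compound 1 to compound 3 (within the scatter), which stayed within the scatter. On that basis the step expected in this assay is a number 3.3 percentage points lower from compound 2 to compound 4 (within the scatter), nothing beyond the scatter. Compound 4 is therefore estimated at 38%, with a range from 24% to 52%.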

Compound 4, a percentage reported as inhibition, at one concentration (the size of the read-out at that concentration, not a potency): 33%
The estimate for compound 4 lay 5 percentage points above the measured number; the range from low to high includes it.
By their numbers in this assay, from the lowest: compounds 4, 3, 2 and 1 (each within the scatter of the next, the first and the last beyond it).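

In this assay the exchange of 3,4-dimethylphenyl for 5-bromo-2-methoxyphenyl on the nitrogen gives a number 8.3 percentage points lower from compound 2 to compound 4 (within the scatter), so the entering group, with its bromine and its hydrogen-bond acceptor, does not separate the two compounds. Together with a number 10 percentage points lower from compound 1 to compound 3 (within the scatter), this makes two exchanges on this nitrogen, in two different molecular settings, and neither leaves the scatter. Nothing measured here accounts for the size of either step. The compounds shown leave open whether an amine or a carboxylic acid on this ring, or a longer chain in its place, would move the number beyond the scatter.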